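A few compounds are considered here, and "the series" means these few. Any claim that something is new, unique, unknown or untested is made for them only; others in the source may bear on it.

Compound 1 `Cc1ccc2nc(NC(=O)c3cn(-c4ccccc4)nc3-c3ccc(Cl)cc3)sc2c1` gives 23700 nM in a functional assay on HT-29 cells (Homo sapiens) for cytotoxicity, read by MTT assay, with a stated time of 72 h; on this read-out lower numbers stand for stronger inhibition and higher numbers for weaker inhibition; compound 2 `COc1ccc(-c2nn(-c3ccccc3)cc2C(=O)Nc2nc3ccccc3s2)cc1` gives 10500 nM; compound 3 `COc1ccc(-c2nn(-c3ccccc3)cc2C(=O)Nc2nc3ccc(F)cc3s2)cc1` gives 5560 nM.

Compound 3 holds the lowest of the three numbers in this assay. Its gap to compound 2 lies within the scatter, whereas compound 1 stands beyond it, so compound 3 cannot be called the most potent of the set. Compound 4 `COc1ccc(-c2nn(-c3ccccc3)cc2C(=O)Nc2nc3ccc(C)cc3s2)cc1` differs from compound 3 by methyl in place of fluoro on an aromatic carbon. Going by the values given here, only one measured step concerns that position: a 1.9-fold lower number from compound 2 to compound 3 (0.28 log units; within the scatter), and it stayed within the scatter. Among the compounds with values here, compound 1 also carries a methyl there, but it differs from compound 3 in a second place as well, so its value shows only that the pair sits apart. The expected step is therefore a 1.3-fold higher number from compound 3 to compound 4 (0.10 log units; within the scatter), no change beyond the scatter. Compound 4 is estimated at 7000 nM, between 2500 nM and 20000 nM.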

Compound 4, half-maximal inhibitory concentration: 21500 nM
Estimate against measurement, compound 4: 3.1-fold (0.49 log units) below; the measured number lies above the stated range.
By their numbers in this assay, from the lowest: compounds 3 and 2 (each within the scatter of the next); then compounds 4 and 1 (each within the scatter of the next).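

Going by these compounds alone, replacing 6-fluoro-1,3-benzothiazol-2-yl with 6-methyl-1,3-benzothiazol-2-yl gives a 3.9-fold higher number from compound 3 to compound 4 (0.59 log units; beyond the scatter) in this assay and is the first change at this position to pass the scatter. Methyl in place of hydrogen gives a 2.0-fold higher number from compound 2 to compound 4 (0.31 log units; beyond the scatter) and also passes it, so this position is not indifferent to what it carries. With methyl held there, methoxy in place of chloro on an aromatic carbon gives a 1.1-fold lower number from compound 1 to compound 4 (0.04 log units; within the scatter) and no real change.

No measured evidence accounts for these steps.
From the compounds shown here alone, whether an amine or a carboxylic acid at this position would track with fluoro or with methyl remains open.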